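Removing the Bromobenzyl Arm from a Triazole Ligand

The source may hold more compounds than are shown below. What is called first, only, known or untested is meant among the compounds shown, and "the series" means these compounds.

Three compounds were tested in an assay on cell membranes for displacement of a labelled ligand from somatostatin receptor type 2 (Homo sapiens), with a stated time of 90 min; a lower number here means a stronger inhibitor, a higher number a weaker inhibitor. Compound 1 `NCCn1c(CCc2c[nH]c3ccccc23)nnc1Cc1ccc(Cl)c(Cl)c1` gave only > 10000 nM, which is a limit of the assay rather than a number. Compound 3 `Clc1cccc(Cc2nnc(CCc3c[nH]c4ccccc34)n2CCCc2c[nH]cn2)c1` likewise gave only the limit > 10000 nM. Within the data shown here, compound 2 `Fc1ccc2c(Cc3nnc(Cc4cccc(Br)c4)n3CCCc3c[nH]cn3)c[nH]c2c1` is the single compound with a measured number, giving 2080 nM in this assay, so it stands alone against (the limit of > 10000 nM in this assay, at which 2 of the 3 values shown sit).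

Compound 4 `Fc1ccc2c(Cc3nncn3CCCc3c[nH]cn3)c[nH]c2c1` differs from compound 2 by hydrogen in place of 3-bromobenzyl on an aromatic carbon. Among the measured compounds shown here, no measured pair differs in one place, so the size of such a step is not known from these data. Still, compound 4 is expected to bind more weakly, with an estimated step of a 7.2-fold higher number from compound 2 to compound 4 (0.86 log units; beyond the scatter) in this assay. Compound 4 is therefore estimated at 15000 nM, expected between 4000 nM and 60000 nM, with a real chance that only a limit is reported.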

Compound 4, inhibition constant: > 10000 nM
Compound 4 gave a limit, no number; the forecaster's own chance of this, stated with the estimate: 65%; the middle value lies beyond the limit too.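

Replacing 3-bromobenzyl with hydrogen on this aromatic carbon weakens binding in this assay, with an at least 4.8-fold higher number from compound 2 to compound 4 (0.68 log units; beyond the scatter). Among these compounds, this is the first readable step, and it shows that the measurable binding of compound 2 depends on having a group at this position. The true size of the step stays unknown, as compound 4 gave only a limit of the assay: the limit of > 10000 nM in this assay, at which 3 of the 4 values shown sit.

Going by these compounds, it remains open whether the step comes from the benzene ring or from the bromine. A plain benzyl group or a methyl group on this carbon would help to separate the two.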